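The source may report more compounds than this note shows. Statements on the series, on what has been measured and on what is new or still open speak of the compounds shown alone.

Measured in an in vitro ADME assay on microsomes from liver (Mus musculus) for pharmacokinetics, read by LC-MS, with a stated time of 10 min, tested at 1 uM; on this read-out lower numbers stand for slow clearance and higher numbers for fast clearance:
compound 1 `CC(C)(C)N1C[C@H](C(=O)Nc2ccc(Cl)cc2)[C@@H](c2ccc(/C=C/C(=O)Nc3ccccc3N)cc2)C1`: 20 mL/min/kg
compound 2 `N#CCN1C[C@H](C(=O)Nc2ccc(Cl)cc2)[C@@H](c2ccc(/C=C/C(=O)Nc3ccccc3N)cc2)C1`: 51 mL/min/kg

Of these two numbers, compound 2 holds the higher, at 51 mL/min/kg. The next compound, compound 3 `CCNC(=O)N1C[C@H](C(=O)Nc2ccc(Cl)cc2)[C@@H](c2ccc(/C=C/C(=O)Nc3ccccc3N)cc2)C1`, carries ethylcarbamoyl in place of cyanomethyl on an amine nitrogen in a ring. Within the data shown here, one measured step bears on this, made on the same amine nitrogen: a 2.6-fold higher number from compound 1 to compound 2 (0.41 log units; beyond the scatter). That step is modest but beyond the scatter, so changes at this nitrogen have moved the read-out in this assay by a modest amount in the one case available. Among the measured compounds shown here, no measured compound carries ethylcarbamoyl, and the direction is therefore poorly defined. A step of similar or smaller size is expected, leaning slightly downward since compound 2 has the higher number at 51 mL/min/kg. The expected change is a 1.3-fold lower number from compound 2 to compound 3 (0.11 log units; within the scatter), which would not clearly exceed the scatter. For compound 3 the estimated clearance is 40 mL/min/kg, with an expected range of 18 mL/min/kg to 85 mL/min/kg.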

Compound 3, clearance: 25 mL/min/kg
For compound 3 the middle estimate is 1.6-fold (0.20 log units) above the measured one; the measured number falls inside the stated range.
By their numbers in this assay, from the lowest: compounds 1 and 3 (each within the scatter of the next); then compound 2.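

In this assay the swap of cyanomethyl for ethylcarbamoyl on the amine nitrogen in a ring shows a 2.0-fold lower number from compound 2 to compound 3 (0.31 log units; beyond the scatter), a modest step opposite in direction to the one already seen, a 2.6-fold higher number from compound 1 to compound 2 (0.41 log units; beyond the scatter). The comparison with tert-butyl shows a 1.3-fold higher number from compound 1 to compound 3 (0.10 log units; within the scatter), so ethylcarbamoyl and tert-butyl are not separated on this read-out, although they differ in name and in their counted atoms, and among these three groups only cyanomethyl stands apart. Nothing available explains this pattern.

From the compounds shown here alone, whether the lower numbers extend to other groups on this nitrogen, such as an acetyl group, a longer alkyl chain or a carboxylic acid, remains open. Going by these compounds, whether cyanomethyl would stand apart in the same way on a different core also remains open.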